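The source may hold more compounds than are shown below. What is called first, only, known or untested is meant among the compounds shown, and "the series" means these compounds.

Compound 1 `COc1cccc(/C=C/C(=O)c2ccc(OC)c3c2OC(C)(C)C=C3)c1` — in a functional assay on K562 cells (Homo sapiens) for antiproliferative activity, read by MTT assay, with a stated time of 24 h (on this read-out lower numbers stand for stronger inhibition and higher numbers for weaker inhibition), compound 1 gives > 10000 nM, a limit of the assay.
Compound 2 `COc1ccc(/C=C/C(=O)c2ccc(OC)c3c2OC(C)(C)C=C3)c(F)c1` — in this assay compound 2 gives > 10000 nM, a limit of the assay.

For the measured compounds named here, compound 2 therefore stands at the limit of this assay, and the only measured step, from compound 1 to compound 2, is a step that the two limits leave unreadable from compound 1 to compound 2. Both values shown sit at the same limit, as the limit of > 10000 nM in this assay, at which 2 of the 2 values shown sit, records, so no readable step exists among the measured compounds.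

Compound 3 `COc1ccc(C(=O)/C=C/c2ccc(F)cc2)c2c1C=CC(C)(C)O2` differs from compound 2 by 4-fluorophenyl in place of 2-fluoro-4-methoxyphenyl on a double-bonded chain carbon bound to a double-bonded chain carbon. The structural change takes away the methoxy part of the 2-fluoro-4-methoxyphenyl group and moves the fluorine, leaving a 4-fluorophenyl group on the double-bonded chain carbon. Going by the values given here, no measured step bears on this change: the step from compound 1 to compound 2 altered the same position, yet both of its ends are limits, so its size is not known. With nothing to guide the direction, compound 3 is expected to remain near the limit, and the step from compound 2 to compound 3 in this assay is estimated as a step that the limit leaves unreadable from compound 2 to compound 3. Compound 3 is estimated at 15000 nM, between 3000 nM and 60000 nM, with a high chance that only a limit is reported.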

Compound 3, half-maximal inhibitory concentration: > 10000 nM
Compound 3: only a limit was reported; the forecaster's own chance of this, stated with the estimate: 75%; the middle value does not contradict the limit.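

Compound 3, like compound 1 and compound 2, gives only a limit in this assay, so the steps from compound 2 to compound 3 and from compound 1 to compound 3 cannot be read: the limit of > 10000 nM in this assay, at which 3 of the 3 values shown sit.

The compounds shown leave open how the three groups on the double-bonded chain carbon differ in antiproliferative activity, and whether any group there gives a readable value.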